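A few compounds are considered here, and "the series" means these few. Any claim that something is new, unique, unknown or untested is made for them only; others in the source may bear on it.

Among the compounds with values here, compound 2 `Clc1cccc2c1nnn2CC1CC1` gives the lower of the two numbers so far in a functional assay on cells for positive allosteric modulation of metabotropic glutamate receptor 2 (Homo sapiens), read by fluorescence and calcium flux, with a stated time of 30 min; on this read-out lower numbers stand for an effect already at smaller amounts and higher numbers for an effect only at larger amounts of compound: compound 2 shows 90 nM, while compound 1 `Brc1ccc(Cn2nnc3c(Br)cccc32)cn1` shows 210 nM, a gap that lies beyond the usual scatter. Within the data shown here, no step between measured compounds that differ in one place is available. Compound 3 `FC(F)(F)c1cccc2c1nnn2CC1CC1` carries trifluoromethyl in place of chloro on an aromatic carbon. Among the measured compounds shown here, with no measured precedent for this exchange, the step of a 1.3-fold higher number from compound 2 to compound 3 (0.12 log units; within the scatter) is expected to be small, probably not beyond the scatter, in either direction. Compound 3 is accordingly estimated at 120 nM, with a plausible range from 40 nM to 400 nM.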

Compound 3, half-maximal effective concentration: 148 nM
Compound 3: the middle estimate sits 1.2-fold (0.09 log units) below what was measured; low and high end bracket the measured number.
By their numbers in this assay, from the lowest: compounds 2, 3 and 1 (each within the scatter of the next, the first and the last beyond it).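

In this assay, within the data shown here, trifluoromethyl in place of chloro on an aromatic carbon gives a 1.6-fold higher number from compound 2 to compound 3 (0.22 log units; within the scatter), the first step that isolates this position. The two groups cannot be told apart on this read-out, so this exchange is tolerated here. Nothing available explains this result.

On these data alone, whether the position tolerates groups of another kind, such as an amine, a nitrile or a methoxy group, stays open. So does whether trifluoromethyl and chloro would also read alike on the core of compound 1.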